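The compounds below may be only part of what the source reports. "The series", "measured", "known", "first", "only" and "open" are said of these compounds alone.

Measured in an ADME assay on 184B5 cells (Homo sapiens) for cytotoxicity, read by MTT assay, with a stated time of 72 h; a lower number here means a stronger inhibitor of growth, a higher number a weaker inhibitor of growth:
compound 1, `CSc1ccc(CNc2nc(SC)nc3ncccc23)cc1`, gives 1140 nM.
compound 3, `CSc1ccc(CNc2nc([SeH])nc3ccccc23)cc1`, gives 86300 nM.
compound 2, `COc1ccc(CNc2nc([SeH])nc3ccccc23)cc1`, gives > 100000 nM, which is a limit of the assay and not a number.

The value of compound 2 sits at the limit of > 100000 nM in this assay, at which 1 of the 3 values shown sits. From compound 3 to compound 2 the change is methoxy in place of methylsulfanyl on an aromatic carbon and the step in this assay is an at least 1.1-fold higher number from compound 3 to compound 2 (0.06 log units; that floor lies within the scatter). Compound 1 holds the lowest of the two numbers; the difference between its core and the core of compound 3 is not broken down here, so the gap between compound 1 and compound 3 is only what their two values show.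

Compound 4, `COc1ccc(CNc2nc(SC)nc3ncccc23)cc1`, is not yet measured in this assay. Within the data shown here, from compound 1 it differs by methoxy in place of methylsulfanyl on an aromatic carbon, the same change as the one from compound 3 to compound 2, at the same kind of place. Because the measured step was an at least 1.1-fold higher number from compound 3 to compound 2 (0.06 log units; that floor lies within the scatter), the change is expected to move the number of compound 1 little. The expected step is a 1.3-fold higher number from compound 1 to compound 4 (0.12 log units; within the scatter). Compound 4 is expected to give about 1500 nM, estimated between 600 nM and 4500 nM.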

Compound 4, concentration for total growth inhibition: 69800 nM
For compound 4 the middle estimate is 47-fold (1.67 log units) below the measured one, and the stated range ends below it.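

In this assay, methoxy in place of methylsulfanyl on an aromatic carbon of the core of compound 1 gives a 61-fold higher number from compound 1 to compound 4 (1.79 log units; beyond the scatter), so on this core the swap is a large step and not a neutral one. Compound 2 gives > 100000 nM, which is a limit of the assay and not a number. The pairs therefore show neither that the step carries over from one core to the other with the same size nor that its size depends on the core: the same change on two cores in this assay, an at least 1.1-fold higher number (0.06 log units; that floor lies within the scatter) from compound 3 to compound 2 and a 61-fold higher number (1.79 log units; beyond the scatter) from compound 1 to compound 4; the limit leaves it open whether they differ

The compounds shown leave open whether the large step seen on the core of compound 1 would recur on any further core, since only these two pairs carry the change. They also leave open how other groups at this place, para to a large group, such as an amine, a hydroxyl or a longer chain like ethylsulfanyl, would stand against methylsulfanyl and methoxy in this assay.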